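The source may hold more compounds than are shown below. What is called first, only, known or untested is meant among the compounds shown, and "the series" means these compounds.

Compound 2 `COc1cc(N(Cc2ccccc2)S(=O)(=O)c2ccc(C)cc2)cc(OC)c1OC` gives 3570 nM in a functional assay on MGC-803 cells (Homo sapiens) for inhibition, read by MTT assay, with a stated time of 48 h; a higher number here means a weaker inhibitor, a lower number a stronger inhibitor. Compound 1 `COc1cc(N(Cc2cccc(C)c2)S(=O)(=O)c2ccc(C)cc2)cc(OC)c1OC` carries methyl in place of hydrogen on an aromatic carbon, and in this assay compound 1 gives 4340 nM; the step of a 1.2-fold higher number from compound 2 to compound 1 (0.08 log units; within the scatter). Compound 3 `Cc1ccc(S(=O)(=O)N(Cc2nc3ccccc3[nH]2)c2ccccc2)cc1` is built on a different core, and the difference between the two cores is not broken down here. In this assay compound 3 gives 45200 nM, a number that lies beyond the scatter above both compound 1 and compound 2. Compound 4 `Cc1ccc(N(Cc2nc3ccccc3[nH]2)S(=O)(=O)c2ccc(C)cc2)cc1` carries methyl in place of hydrogen on an aromatic carbon. This is the same kind of change as that made from compound 2 to compound 1, not the same: in compound 1 the methyl sits meta to a large group, in compound 4 para to a large group. For compound 4 a step of a 1.1-fold higher number from compound 3 to compound 4 (0.04 log units; within the scatter) is expected, because the step of a 1.2-fold higher number from compound 2 to compound 1 (0.08 log units; within the scatter) stayed within the scatter. Compound 4 is therefore estimated at 50000 nM, between 20000 nM and 130000 nM.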

Compound 4, half-maximal inhibitory concentration: 41300 nM
Compound 4: the middle estimate sits 1.2-fold (0.08 log units) above what was measured; the range from low to high includes it.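

In this assay the change from phenyl to 4-methylphenyl gives a 1.1-fold lower number from compound 3 to compound 4 (0.04 log units; within the scatter) and so makes no readable difference on this core. Set beside the earlier step, the same change behaves alike on the two cores: the same change on two cores in this assay, a 1.2-fold higher number (0.08 log units; within the scatter) from compound 2 to compound 1 and a 1.1-fold lower number (0.04 log units; within the scatter) from compound 3 to compound 4, 1.3-fold (0.12 log units) apart, within the scatter of two such steps. This covers one small group on two cores only, with the methyl not standing in the same place on each, and it does not show that the methyl would behave alike elsewhere on either core or that a larger group would carry over in this way.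

The compounds shown leave open whether an amine, a carboxylic acid or a longer chain in place of the methyl would shift the number on either core. They also leave open which part of the two cores sets their numbers apart.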